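Ring-nitrogen substituent in a benzimidazole-linked oxindole series

The compounds below may be only part of what the source reports. "The series", "measured", "known", "first", "only" and "open" are said of these compounds alone.

Measured so far in a functional assay on 4T1 cells (Homo sapiens) for cytotoxicity, read by MTT assay, with a stated time of 48 h; on this read-out higher numbers stand for weaker inhibition and lower numbers for stronger inhibition:
compound 1, `CCn1c(/C=C2/C(=O)Nc3ccccc32)nc2ccccc21`, > 50000 nM
compound 2, `CCn1c(/C=C2/C(=O)Nc3ccc(Br)cc32)nc2ccccc21`, 40700 nM
compound 3, `CCn1c(/C=C2/C(=O)Nc3ccc(C)cc32)nc2ccccc21`, 39400 nM

The value of compound 1 is a limit of this assay, not a number (the limit of > 50000 nM in this assay, at which 1 of the 3 values shown sits). Among the two numbers, compound 2 gives the higher one, and its nearest neighbour is compound 3 a 1.0-fold lower number from compound 2 to compound 3 (0.01 log units; within the scatter), so the two stand together within the scatter. The steps from compound 1, an at least 1.2-fold lower number from compound 1 to compound 2 (0.08 log units; that floor lies within the scatter) and an at least 1.2-fold lower number from compound 1 to compound 3 (0.10 log units; that floor lies within the scatter), carry floors that lie within the scatter as well.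

Compound 4, `Cn1c(/C=C2/C(=O)Nc3ccc(Br)cc32)nc2ccccc21`, is reached from compound 2 by hydrogen in place of methyl on a saturated chain carbon bound to an aromatic nitrogen; the same difference, cut one bond further out, reads ethyl to methyl. Within the data shown here, none of the measured steps touches this position: all three change the group on the aromatic carbon. Among the measured compounds shown here, there is therefore no measured step to size the change by, and the expectation for this assay is a step no larger than the scatter, in no set direction. The step from compound 2 to compound 4 is estimated as a 1.0-fold lower number from compound 2 to compound 4 (0.01 log units; within the scatter). Compound 4 is expected to give 40000 nM in this assay, with a range from 15000 nM to 100000 nM, and a real chance that only a limit is reported.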

Compound 4, half-maximal inhibitory concentration: > 50000 nM
Compound 4: a limit, no number; the forecaster's own chance of this, stated with the estimate: 35%; at least 1.2-fold (0.09 log units) between middle value and limit.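

The ethyl to methyl change on a saturated chain carbon bound to an aromatic nitrogen now has its first reading in this assay, and it is an at least 1.2-fold higher number from compound 2 to compound 4 (0.08 log units; that floor lies within the scatter). Among these compounds, the value of compound 4 is a limit of the assay, not a number, so the size of this change stays unknown: the limit of > 50000 nM in this assay, at which 2 of the 4 values shown sit. The earlier compounds varied only the group on the aromatic carbon, and this step adds that going from ethyl to methyl with the bromo group held brings no lower number in this assay.

Open, as far as these compounds go, is whether a longer chain, a benzyl group or a chain ending in an amine on this nitrogen would give a number clear of the limit. Also open, from the compounds shown here alone, is whether the ethyl to methyl change reads the same with methyl or hydrogen in place of bromo on the aromatic carbon.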